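The source may report more compounds than this note shows. Statements on the series, on what has been measured and on what is new or still open speak of the compounds shown alone.

Measured to date in an assay on CHO cells for displacement of a labelled ligand from adenosine receptor A3 (Homo sapiens), read by scintillation counting, with a stated time of 120 min, tested at 10 uM; on this read-out lower numbers stand for less inhibition and higher numbers for more inhibition at the one concentration tested (going by the name of the read-out):

compound 1 `Nc1scc(CN2CCN(c3ccc(Cl)cc3F)CC2)c1C(=O)c1ccc(Cl)cc1`: compound 1 gives 1%
compound 2 `Nc1scc(CN2CCN(c3ccc(Cl)c(C(F)(F)F)c3)CC2)c1C(=O)c1ccc(Cl)cc1`: compound 2 gives 3%
compound 3 `Nc1scc(CN2CCN(c3cc(F)ccc3F)CC2)c1C(=O)c1ccc(Cl)cc1`: compound 3 gives 2%

All three share the same core and differ only in the aryl group on the ring amine nitrogen. Compound 3 stands second highest of the three numbers, but the spread is small: a number 1 percentage points higher from compound 1 to compound 3 (within the scatter) and a number 1 percentage points lower from compound 2 to compound 3 (within the scatter), both within the scatter, as is a number 2 percentage points higher from compound 1 to compound 2 (within the scatter). Among the measured compounds shown here, no aryl variation so far has moved this assay beyond noise.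

Compound 4 `Nc1scc(CN2CCN(c3ccccc3Cl)CC2)c1C(=O)c1ccc(Cl)cc1` carries the change (2-chlorophenyl in place of 2,5-difluorophenyl on an amine nitrogen in a ring). The three measured steps bear directly on it, since each swaps one substituted phenyl for another on the same ring nitrogen, and none exceeded the scatter. On that basis the step to compound 4 is expected to be no change at the digits printed from compound 3 to compound 4 (within the scatter), with nothing beyond the scatter anticipated in either direction.

Compound 4 is therefore estimated at 2% in this assay, expected to fall between 0% and 12%.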

Compound 4, a percentage reported as inhibition, at one concentration (the size of the read-out at that concentration, not a potency): 0%
Beside the measured number, compound 4's estimate is 2 percentage points above it; the range from low to high includes it.
By their numbers in this assay, from the lowest: compounds 4, 1, 3 and 2 (each within the scatter of the next).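

In this assay, 2-chlorophenyl on the amine nitrogen in the ring shows a number 2 percentage points lower from compound 3 to compound 4 (within the scatter) and a number 3 percentage points lower from compound 2 to compound 4 (within the scatter) and also a number 1 percentage points lower from compound 1 to compound 4 (within the scatter) so a phenyl bearing one chlorine alone behaves like the phenyl groups bearing two or more substituents. Across compounds 1 to 4, the fluoro, chloro and trifluoromethyl patterns on this phenyl therefore cannot be told apart, and the series offers no ranking at this position. Nothing available accounts for this flat result.

Still open, as far as these compounds go, is whether a phenyl bearing a carboxylic acid or an amine, or a simple alkyl chain in place of the phenyl, would carry the number beyond the scatter. Also open, from the compounds shown here alone, is whether replacing the 4-chlorobenzoyl group on the shared core would do so.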